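Cyclopropyl in place of isopropyl: a step expected within scatter

The source may report more compounds than this note shows. Statements on the series, on what has been measured and on what is new or still open speak of the compounds shown alone.

Compound 1 `CC(C)(C)OC(=O)CCC[N+]1(C)CCc2c(sc(NC(=O)Nc3ccc(Cl)cc3)c2C(N)=O)C1` gives 250 nM
Compound 2 `CC(C)C[N+]1(C)CCc2c(sc(NC(=O)Nc3ccc(Cl)cc3)c2C(N)=O)C1` gives 380 nM

Among the compounds with values here, in a functional assay (strain AB) with Danio rerio as the target, read by microscopy, with a stated time of 1 h (on this read-out lower numbers stand for an effect already at smaller amounts and higher numbers for an effect only at larger amounts of compound), compound 2 gives 380 nM as one of only two numbers, and it cannot be told apart from compound 1. The measured step between them (a 1.5-fold higher number from compound 1 to compound 2 (0.18 log units; within the scatter)) puts isopropyl in place of 2-(tert-butoxycarbonyl)ethyl.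

Compound 3 `C[N+]1(CC2CC2)CCc2c(sc(NC(=O)Nc3ccc(Cl)cc3)c2C(N)=O)C1` has not yet been measured. It carries cyclopropyl in place of isopropyl on a saturated chain carbon bound to an amine nitrogen in a ring. Cut one bond further out, the same difference reads isobutyl to cyclopropylmethyl.

Within the data shown here, only one measured step bears on this change, the one at that same place between compound 1 and compound 2 (a 1.5-fold higher number from compound 1 to compound 2 (0.18 log units; within the scatter)). It stayed within the scatter, so no step beyond the scatter is expected in this assay on this slim evidence. The expected step is correspondingly small (a 1.1-fold lower number from compound 2 to compound 3 (0.04 log units; within the scatter)). For compound 3 the estimated value is 350 nM with an expected range from 170 nM to 700 nM on this reasoning.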

Compound 3, half-maximal effective concentration: 360 nM
Estimate against measurement, compound 3: 1.0-fold (0.01 log units) below; measured number inside the range.
By their numbers in this assay, from the lowest: compounds 1, 3 and 2 (each within the scatter of the next).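

In this assay, putting cyclopropyl in place of isopropyl on a saturated chain carbon bound to an amine nitrogen in a ring gives a 1.1-fold lower number from compound 2 to compound 3 (0.02 log units; within the scatter), so a three-membered ring of carbon only and the open isopropyl group cannot be told apart here. The wider comparison gives a 1.4-fold higher number from compound 1 to compound 3 (0.16 log units; within the scatter), so compounds 1, 2 and 3 all lie within the scatter of one another, even though 2-(tert-butoxycarbonyl)ethyl looks quite different from the two small groups. At this place, then, the three groups shown make no readable difference to the number, and nothing available offers an explanation for how closely they agree.

The compounds shown leave open whether a chain ending in a carboxylic acid or an amine at this same place would also stay within the scatter in this assay. They also leave open whether a larger ring of carbon, such as cyclohexyl, would give a number that can be told apart from those of compound 2 and compound 3.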